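Cytotoxicity notes: benzyl for alkyl on the ring nitrogen

This account rests on a few compounds, and the source may have more. Where it says the series, first, only, none or still open, it means among the compounds named here.

Measured so far:
- compound 2, `CCCC(C)n1nc(-c2cccs2)c(O)c(C2=NS(=O)(=O)c3cc(NS(C)(=O)=O)ccc3N2)c1=O`: > 33000 nM
- compound 1, `CC(C)CCn1nc(-c2cccs2)c(O)c(C2=NS(=O)(=O)c3cc(N(C(C)C)S(C)(=O)=O)ccc3N2)c1=O`: "not determined" (no result reported)

In an ADME assay on Huh-7 cells (Homo sapiens) for cytotoxicity, with a stated time of 72 h (on this read-out higher numbers stand for lower toxicity in this test and lower numbers for higher toxicity in this test), compound 2 reports only a limit, > 33000 nM, not a number. Compound 1 has no result in this assay. The unmeasured compound 3, `CS(=O)(=O)Nc1ccc2c(c1)S(=O)(=O)N=C(c1c(O)c(-c3cccs3)nn(Cc3ccc(F)cc3)c1=O)N2`, differs from compound 2 as shown: 4-fluorobenzyl in place of 1-methylbutyl on an aromatic nitrogen. For the measured compounds named here, no step between measured compounds is available, so no size of change beyond the scatter is expected in this assay. Compound 3 is therefore estimated near the limit, at 33000 nM (range 12000 nM to 80000 nM), the estimated step being a number no higher from compound 2 to compound 3 (the limit leaves the size open).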

Compound 3, half-maximal cytotoxic concentration: > 1000 nM
Compound 3 was reported as a limit; the forecaster's own chance of this, stated with the estimate: 65%; the middle value lies beyond the limit too.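

In this assay compound 2 gives only a limit, > 33000 nM. For the compounds shown here, compound 3 likewise gives only a limit, > 1000 nM, and no step to it from compound 2 can be read. Going by these compounds, whether 4-fluorobenzyl in place of 1-methylbutyl changes this read-out stays open.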